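This account rests on a few compounds, and the source may have more. Where it says the series, first, only, none or still open, it means among the compounds named here.

Among the compounds with values here, compound 3 `Cc1cc(-c2nc(C(F)(F)F)n(CC[C@@H](O)C[C@@H](O)CC(=O)O)c2-c2ccc(F)cc2)cc(C)c1F` stands second highest of the three numbers so far in an assay on microsomes from liver for inhibition of 3-hydroxy-3-methylglutaryl-coenzyme A reductase (Rattus norvegicus) (on this read-out lower numbers stand for stronger inhibition and higher numbers for weaker inhibition), where compound 3 gives 32 nM; compound 1 `Cc1cccc(-c2nc(C(F)(F)F)n(CC[C@@H](O)C[C@@H](O)CC(=O)O)c2-c2ccc(F)cc2)c1` gives 29 nM and compound 2 `O=C(O)C[C@H](O)C[C@H](O)CCn1c(C(F)(F)F)nc(-c2ccc(F)cc2)c1-c1ccc(F)cc1` gives 38 nM, both within the scatter of it. Compound 4 `O=C(O)C[C@H](O)C[C@H](O)CCn1c(C(F)(F)F)nc(-c2cccs2)c1-c1ccc(F)cc1` differs from compound 3 by thiophen-2-yl in place of 4-fluoro-3,5-dimethylphenyl on an aromatic carbon. Within the data shown here, the steps that bear on this change are the other swaps of the same aryl group: a 1.3-fold higher number from compound 1 to compound 2 (0.12 log units; within the scatter), a 1.1-fold higher number from compound 1 to compound 3 (0.04 log units; within the scatter) and a 1.2-fold lower number from compound 2 to compound 3 (0.07 log units; within the scatter), none of them beyond the scatter. Because a 1.3-fold higher number from compound 1 to compound 2 (0.12 log units; within the scatter), a 1.1-fold higher number from compound 1 to compound 3 (0.04 log units; within the scatter) and a 1.2-fold lower number from compound 2 to compound 3 (0.07 log units; within the scatter) all stayed flat in this assay, the step from compound 3 to compound 4 is expected to be a 1.1-fold higher number from compound 3 to compound 4 (0.04 log units; within the scatter), with no shift beyond the scatter foreseen. Compound 4 is therefore estimated at 35 nM, within a range from 15 nM to 85 nM.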

Compound 4, half-maximal inhibitory concentration: 64 nM
Compound 4: middle estimate off by 1.8-fold (0.26 log units), on the low side; low and high end bracket the measured number.
By their numbers in this assay, from the lowest: compounds 1, 3, 2 and 4 (each within the scatter of the next, the first and the last beyond it).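

Among the aryl swaps at this aromatic carbon of the shared core, thiophen-2-yl gives the only step in this assay that leaves the scatter, and only in one comparison: a 2.2-fold higher number from compound 1 to compound 4 (0.34 log units; beyond the scatter). The other two steps stay within it: a 2.0-fold higher number from compound 3 to compound 4 (0.30 log units; within the scatter) and a 1.7-fold higher number from compound 2 to compound 4 (0.23 log units; within the scatter). So a five-membered aromatic ring with 1 hetero atom is accepted here, with at most a modest rise against the 3-methylphenyl group, and no measurement at hand accounts for that rise. The compounds shown leave open how a non-aromatic group such as isopropyl or cyclohexyl, or an aryl ring carrying an amine, would read at this carbon.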